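The source may report more compounds than this note shows. Statements on the series, on what has been measured and on what is new or still open speak of the compounds shown alone.

Measured compounds:
- compound 1 `Cc1ccc(OCCCON2C(N)=NC(N)=NC23CCOCC3)cc1` — "not determined" (no result reported)
- compound 2 `NC1=NC2(CCOCC2)N(OCCCOc2ccc(Cl)cc2)C(N)=N1` — "not determined" (no result reported)
- compound 3 `NC1=NC2(CCOCC2)N(OCCCOc2ccccc2Cl)C(N)=N1` — 88.2%

Three compounds of this series have been examined in an assay on isolated protein for inhibition of Dihydrofolate reductase (Homo sapiens), read by spectrophotometry, using NADPH, with stated times of 5 s and 6 min, tested at 50 uM; a higher number here means a stronger effect of the compound at the concentration tested, a lower number a weaker effect. Compound 1 and compound 2 carry no number: for compound 1 the entry reads "not determined" (no result reported), and for compound 2 it reads "not determined" (no result reported). Going by the values given here, compound 3 is therefore the only member with a measured value, giving 88.2% in this assay; with nothing else to compare it with, its standing cannot be placed, and no step between two measured compounds is available.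

The next compound, compound 4 `Cc1cc(C)cc(OCCCON2C(N)=NC(N)=NC23CCOCC3)c1`, is related to compound 3 by a single change at the aryl end of the chain: 3,5-dimethylphenyl in place of 2-chlorophenyl on an oxygen on a saturated carbon. The change keeps an aromatic ring of carbon only, with no donors or acceptors either way.

Among the compounds with values here, with only one measured value to rest on, the expectation for compound 4 is drawn from compound 3 alone, which gave 88.2%. The step of a number 8.2 percentage points lower from compound 3 to compound 4 (within the scatter) is expected to be small, most likely within the scatter, perhaps a slight weakening. Compound 4 is estimated at 80%, with a range of 55% to 95%.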

Compound 4, a percentage reported as inhibition, at one concentration (the size of the read-out at that concentration, not a potency): 88.6%
The estimate for compound 4 lay 8.6 percentage points below the measured number; measured number inside the range.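

In this assay, going by these compounds alone, placing 3,5-dimethylphenyl in place of 2-chlorophenyl on an oxygen on a saturated carbon gives a number 0.4 percentage points higher from compound 3 to compound 4 (within the scatter) and is the first comparison available. It shows that, for this pair at this one concentration, the read-out does not depend on the chlorine, since an aromatic ring of carbon only with two methyl groups serves as well. Nothing at hand bears on why the two compounds read alike.

Steps involving compound 1 and compound 2 cannot be read, and a single-concentration read-out leaves any difference in potency between compound 3 and compound 4 unresolved. Going by these compounds, whether an amine or a carboxylic acid on the aromatic ring, or a longer chain to the oxygen, would keep this level also remains open.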